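Working notes: 2-cyanophenyl to 3-cyanophenyl

The source may report more compounds than this note shows. Statements on the series, on what has been measured and on what is new or still open speak of the compounds shown alone.

- compound 1 `CC1(C)[C@H]2CC[C@]1(C)N(Cc1cn(-c3cccc(F)c3)nn1)C(=O)C2` gives 80 nM
- compound 2 `CC1(C)[C@H]2CC[C@]1(C)N(Cc1cn(-c3ccccc3C#N)nn1)C(=O)C2` gives 180 nM

In a functional assay on HepG2 cells (Homo sapiens) for inhibition, read by MTT assay, with a stated time of 24 h (a higher number here means a weaker inhibitor, a lower number a stronger inhibitor), compound 2 has the higher of the two numbers, at 180 nM. Compound 3 `CC1(C)[C@H]2CC[C@]1(C)N(Cc1cn(-c3cccc(C#N)c3)nn1)C(=O)C2` carries 3-cyanophenyl in place of 2-cyanophenyl on an aromatic nitrogen. For the measured compounds named here, only one measured step bears on this: a 2.3-fold higher number from compound 1 to compound 2 (0.35 log units; beyond the scatter), a modest one that exchanges 3-fluorophenyl for 2-cyanophenyl. It does not separate the group from its place, so a small step toward a lower number is expected, possibly not clear of the scatter. The estimated step is a 1.8-fold lower number from compound 2 to compound 3 (0.26 log units; within the scatter). The expected value for compound 3 is 100 nM, with an estimated range of 40 nM to 250 nM.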

Compound 3, half-maximal inhibitory concentration: 40 nM
For compound 3 the middle estimate is 2.5-fold (0.40 log units) above the measured one; measured number inside the range.
By their numbers in this assay, from the lowest: compounds 3 and 1 (each within the scatter of the next); then compound 2.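

Moving the nitrile, with 3-cyanophenyl in place of 2-cyanophenyl on the aromatic nitrogen, gives a 4.5-fold lower number from compound 2 to compound 3 (0.65 log units; beyond the scatter) in this assay, so the place of the nitrile on the phenyl ring matters, a point the earlier pair could not separate from the change of group. Cyano in place of fluoro on an aromatic carbon gives a 2.0-fold lower number from compound 1 to compound 3 (0.30 log units; within the scatter), so these two groups are not told apart in this assay. No measurement shown accounts for either step. From the compounds shown here alone, whether an amine or a carboxylic acid in place of the nitrile would keep the lower number remains open.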